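A Hydroxy Analog Within a Series of Weak Inhibitors

The compounds below may be only part of what the source reports. "The series", "measured", "known", "first", "only" and "open" are said of these compounds alone.

Three hydrazones built on a shared core were tested in a functional assay on HL-60 cells (Homo sapiens) for cytotoxicity, read by MTT assay, with a stated time of 72 h; a higher number here means a weaker inhibitor, a lower number a stronger inhibitor. Compound 1 `COc1cc(/C=N/Nc2nc3ccccc3s2)ccc1O` gave only a limit in this assay, namely > 16700 nM. Compound 2 `Fc1ccc(/C=N/Nc2nc3ccccc3s2)c(F)c1` likewise reached only a limit, > 17200 nM. Compound 3 `Cc1ccc(/C=N/Nc2nc3ccccc3s2)c(C)c1` also stopped at a limit, > 17700 nM. Because of the limit of > 16700 nM in this assay, at which 1 of the 3 values shown sits, the limit of > 17200 nM in this assay, at which 1 of the 3 values shown sits, and (the limit of > 17700 nM in this assay, at which 1 of the 3 values shown sits), compound 1 cannot be ranked against the other two; all three sit at the edge of what this assay can report, and none of them shows an actual number.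

Compound 4 `Oc1ccc(/C=N/Nc2nc3ccccc3s2)cc1` has not yet been measured. It differs from compound 1 by hydrogen in place of methoxy on an aromatic carbon. Among the compounds with values here, no two measured compounds differ in only one place, so no measured step can guide the expectation. The step from compound 1 to compound 4 is therefore expected to stay within the usual scatter, as a step that the limit leaves unreadable from compound 1 to compound 4. Compound 4 is estimated at 20000 nM, with a range from 8000 nM to 50000 nM, and this assay is most likely to report only a limit again.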

Compound 4, half-maximal inhibitory concentration: 4600 nM
Compound 4: the middle estimate sits 4.3-fold (0.64 log units) above what was measured; the whole stated range lies above it.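

On this aromatic carbon, ortho to a hydroxy group, hydrogen in place of methoxy gives an at least 3.6-fold lower number from compound 1 to compound 4 (0.55 log units; beyond the scatter) in this assay. Within the data shown here, this is the first change that can be read at all, and it shows that this one position can move the result beyond the usual scatter of the assay. The true size of the step stays unknown, because compound 1 reached only a limit: the limit of > 16700 nM in this assay, at which 1 of the 4 values shown sits.

From the compounds shown here alone, whether an amine or a carboxylic acid on this same carbon would give a number like that of compound 4, or a limit like that of compound 1, remains open. Also open is what the hydroxy group itself contributes, since no pair of compounds shown changes that group alone.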